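This account rests on a few compounds, and the source may have more. Where it says the series, first, only, none or still open, it means among the compounds named here.

Measured in a functional assay on CCRF-CEM cells (Homo sapiens), read by MTT assay, with a stated time of 72 h; a lower number here means a stronger inhibitor, a higher number a weaker inhibitor:
- compound 1 `Cc1ncnc2c1c(-c1cccs1)cn2[C@@H]1O[C@H](CO)[C@@H](O)[C@H]1O`: > 20000 nM (a limit)
- compound 2 `Cc1ncnc2c1c(-c1cc3ccccc3o1)cn2[C@@H]1O[C@H](CO)[C@@H](O)[C@H]1O`: 17300 nM
- compound 3 `CNc1ncnc2c1c(I)cn2[C@@H]1O[C@H](CO)[C@@H](O)[C@H]1O`: > 100000 nM (a limit)

Compound 3 stands at > 100000 nM, which is a limit of this assay and not a number. In compound 4 `Cc1ncnc2c1c(I)cn2[C@@H]1O[C@H](CO)[C@@H](O)[C@H]1O`, methyl takes the place of methylamino on an aromatic carbon (methyl in place of methylamino on an aromatic carbon). Among the measured compounds shown here, no measured step covers this swap directly. For the measured compounds named here, the only measured step, an at least 1.1-fold lower number from compound 1 to compound 2 (0.06 log units; that floor lies within the scatter), concerns a different group and says little about this change. The indirect evidence is that compound 2, which carries methyl at this place but a different group elsewhere, gives 17300 nM. Compound 1 also carries methyl there, and its > 20000 nM is likewise a limit. A lower number than the limit of compound 3 is therefore expected in this assay, though the iodo compound may still reach a limit. The expected change is an at least 5.0-fold lower number from compound 3 to compound 4 (0.69 log units; beyond the scatter). For compound 4 the estimated value is 20000 nM, with an expected range from 4000 nM to 100000 nM.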

Compound 4, half-maximal inhibitory concentration: 5480 nM
For compound 4 the middle estimate is 3.6-fold (0.56 log units) above the measured one, within the range that was stated.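

In this assay, among the compounds shown here, with iodo held in place, the swap of methylamino for methyl on an aromatic carbon gives an at least 18-fold lower number from compound 3 to compound 4 (1.26 log units; beyond the scatter), the first direct reading of a change at this position. Compound 3 stands at a limit and not a number, so this step is a floor: the limit of > 100000 nM in this assay, at which 1 of the 4 values shown sits. With methyl held, iodo in place of 1-benzofuran-2-yl gives a 3.2-fold lower number from compound 2 to compound 4 (0.50 log units; beyond the scatter), and iodo in place of thiophen-2-yl gives an at least 3.6-fold lower number from compound 1 to compound 4 (0.56 log units; beyond the scatter), the second also a floor as compound 1 stands at a limit: the limit of > 20000 nM in this assay, at which 1 of the 4 values shown sits.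

The compounds shown leave open whether an unsubstituted amine, a methoxy group or an ethyl group at the methyl position would give a number like that of compound 4. They also leave open whether the methyl-for-methylamino step holds with thiophen-2-yl or 1-benzofuran-2-yl in place of iodo.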